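The source may hold more compounds than are shown below. What is called first, only, known or untested is meant among the compounds shown, and "the series" means these compounds.

Among the compounds with values here, compound 3 `Cc1nc(Nc2cc(Cl)c(C#N)cc2Cl)c(=O)n(C(C)C2CC2)n1` gives 270 nM in an assay on isolated protein for displacement of a labelled ligand from corticotropin-releasing factor receptor 1 (Rattus norvegicus) (a lower number here means a stronger inhibitor, a higher number a weaker inhibitor), the highest of the three numbers measured so far. Compound 1 `COCC(C1CC1)n1nc(C)nc(Nc2c(Cl)cc(OC(F)(F)F)cc2Cl)c1=O` gives 11 nM in this assay, and compound 2 `CCC(C1CC1)n1nc(C)nc(Nc2cc(C)c(C#N)cc2C)c1=O` gives 9.3 nM, so compound 3 sits well beyond the scatter from both, the weaker binder of the set. Compound 4 `Cc1nc(Nc2c(Cl)cc(C#N)c(Cl)c2Cl)c(=O)n(C(C)C2CC2)n1` differs from compound 3 by chloro in place of hydrogen on an aromatic carbon. Within the data shown here, no step between measured compounds isolates this change, but compound 3, with 270 nM, carries fewer groups on that ring than compound 1, with 11 nM, which suggests the added chloro is more likely to lower the number than to raise it. Compound 4 is therefore expected to give about 40 nM, plausibly between 8 nM and 200 nM, a step of a 6.8-fold lower number from compound 3 to compound 4 (0.83 log units; beyond the scatter) being the estimate.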

Compound 4, half-maximal inhibitory concentration: 10 nM
Estimate against measurement, compound 4: 4.0-fold (0.60 log units) above; the measured number falls inside the stated range.
By their numbers in this assay, from the lowest: compounds 2, 4 and 1 (each within the scatter of the next); then compound 3.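

Across this assay, the chloro in place of hydrogen gives a 27-fold lower number from compound 3 to compound 4 (1.43 log units; beyond the scatter), the first change in one place among these compounds. The step lies beyond the scatter, so this aromatic carbon, ortho to a chloro group and meta to a cyano group, is sensitive to what it carries. No measurement shown bears on the reason for this step.

On these data alone, what fluoro, methyl or methoxy would do at this carbon stays open. So does whether chloro gives a step of this size with another side chain on the shared core.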